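From Nitro to Chloro in a Weakly Cytotoxic Series

This account rests on a few compounds, and the source may have more. Where it says the series, first, only, none or still open, it means among the compounds named here.

Measured so far in a functional assay on HCT-116 cells (Homo sapiens) for cytotoxicity, read by MTT assay; a lower number here means a stronger inhibitor, a higher number a weaker inhibitor
compound 1 `Cc1cc(O)c(C(=O)/C=C/c2ccccc2F)c(=O)o1` (> 100000 nM)
compound 2 `Cc1cc(O)c(C(=O)/C=C/c2ccccc2[N+](=O)[O-])c(=O)o1` (> 100000 nM)
compound 3 `Cc1cc(O)c(C(=O)/C=C/c2ccc(Cl)cc2)c(=O)o1` (87400 nM)

In this assay compound 2 has only a limit and no number (> 100000 nM). Compound 1 likewise has only a limit (> 100000 nM). Both sit at the same mark (the limit of > 100000 nM in this assay, at which 2 of the 3 values shown sit). Compound 3 gives a number (87400 nM).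

Compound 4 (`Cc1cc(O)c(C(=O)/C=C/c2ccccc2Cl)c(=O)o1`) differs from compound 2 by chloro in place of nitro on an aromatic carbon, ortho to a large group (chloro in place of nitro on an aromatic carbon). Going by the values given here, the one measured step that exchanges a group at such a place is unreadable in size (a step that the two limits leave unreadable from compound 1 to compound 2), so it sets no expected size. The expectation rests instead on compound 3, which also carries chloro and gives a number (87400 nM). A small step towards stronger inhibition in this assay is therefore expected, possibly none beyond the scatter. The expected step is modest (an at least 1.1-fold lower number from compound 2 to compound 4 (0.04 log units; that floor lies within the scatter)). For compound 4 the estimated value is 90000 nM (expected range 40000 nM to 150000 nM).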

Compound 4, half-maximal inhibitory concentration: > 100000 nM
Compound 4: a limit, no number; the forecaster's own chance of this, stated with the estimate: 50%; middle value at least 1.1-fold (0.04 log units) away from the limit.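

In this assay compound 4 gives only a limit (> 100000 nM), and compound 1 and compound 2 also stand at limits, so no step among these three can be read. The compounds shown leave open how far each lies from that limit, and whether chloro, nitro and fluoro on that aromatic carbon differ at all.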